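Removing the Fluorine From an Inactive Analogue

The compounds below may be only part of what the source reports. "The series", "measured", "known", "first", "only" and "open" are said of these compounds alone.

Compound 1 `O=[N+]([O-])c1ccc(-c2cn3nc(Cc4ccc(Cl)cc4)sc3n2)cc1` and compound 2 `Fc1ccc(-c2nc3sc(Cc4ccc(Cl)cc4)nn3c2Br)cc1` were both tested in a functional assay on HeLa cells (Homo sapiens) for cytotoxicity, with a stated time of 72 h; on this read-out higher numbers stand for weaker inhibition and lower numbers for stronger inhibition. Compound 1 gives only a limit in this assay, > 250000 nM. Compound 2 likewise gives only a limit in this assay, > 250000 nM. Both results thus rest on (the limit of > 250000 nM in this assay, at which 2 of the 2 values shown sit). Compound 3 `Clc1ccc(Cc2nn3c(Br)c(-c4ccccc4)nc3s2)cc1` differs from compound 2 by hydrogen in place of fluoro on an aromatic carbon. With both measured compounds at the limit, no step size can be read from the numbers. Compound 3 is expected to stay at the limit, a step of a number no higher from compound 2 to compound 3 (the limit leaves the size open), none beyond the scatter. Compound 3 is therefore estimated at 250000 nM, between 100000 nM and 1000000 nM.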

Compound 3, half-maximal inhibitory concentration: > 250000 nM
Compound 3: no number, only a limit; the forecaster's own chance of this, stated with the estimate: 85%; the middle value sits exactly at the limit.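

Among these compounds, compound 2 and compound 3 both give only a limit, so no step between them can be read. With compound 1 also at a limit, the compounds shown leave open which structural change, if any, would yield a measurable value.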